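Pyridinyloxy in Place of Pyrazolyl on a Sulfonyl Acylguanidine

The source may report more compounds than this note shows. Statements on the series, on what has been measured and on what is new or still open speak of the compounds shown alone.

Of the compounds shown here, two have been measured in a functional assay for inhibition of sodium/hydrogen exchanger (Oryctolagus cuniculus); a lower number here means a stronger inhibitor, a higher number a weaker inhibitor. Going by the values given here, compound 2 `Cc1cc(-n2cccn2)c(S(C)(=O)=O)cc1C(=O)N=C(N)N` gives 25 nM, and the only other value, for compound 1 `Cc1c(C(=O)N=C(N)N)cc(S(C)(=O)=O)c(Oc2cccnc2)c1C`, is 23 nM; the two lie within the scatter of each other. Compound 3 `Cc1cc(Oc2cccnc2)c(S(C)(=O)=O)cc1C(=O)N=C(N)N` remains to be measured. It differs from compound 2 in one place: (pyridin-3-yl)oxy in place of 1H-pyrazol-1-yl on an aromatic carbon The entering group sits ortho to a methylsulfonyl group. Because compound 1 gives 23 nM while carrying the same (pyridin-3-yl)oxy group, compound 3 is expected to show no step beyond the scatter, a 1.3-fold lower number from compound 2 to compound 3 (0.10 log units; within the scatter). In this assay compound 3 is estimated at 20 nM, with a range from 8 nM to 50 nM.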

Compound 3, half-maximal inhibitory concentration: 8.8 nM
For compound 3 the middle estimate is 2.3-fold (0.36 log units) above the measured one; measured number inside the range.
By their numbers in this assay, from the lowest: compound 3; then compounds 1 and 2 (each within the scatter of the next).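

In this assay, (pyridin-3-yl)oxy in place of 1H-pyrazol-1-yl, ortho to the methylsulfonyl group, gives a 2.8-fold lower number from compound 2 to compound 3 (0.45 log units; beyond the scatter), so this position responds to the change of group. Hydrogen in place of methyl on an aromatic carbon gives a 2.6-fold lower number from compound 1 to compound 3 (0.42 log units; beyond the scatter), so with (pyridin-3-yl)oxy held fixed, that methyl site matters too. Nothing shown explains either step.

The compounds shown leave open whether phenoxy, with carbon in place of the pyridine nitrogen, or an amine at this position would match the (pyridin-3-yl)oxy group. They also leave open whether the pyridine nitrogen itself contributes to the step.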